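The compounds below may be only part of what the source reports. "The series", "measured", "known", "first", "only" and "open" are said of these compounds alone.

Working notes on the series. Compound 1 `CC(C)OC(=O)N1CCC(Oc2cccc3c2CCN3c2ccc(S(C)(=O)=O)cc2)CC1` gives 501 nM in a functional assay on CHO-K1 cells for agonist activity at Glucose-dependent insulinotropic receptor (Homo sapiens), read by a luciferase reporter, with a stated time of 5 h; a lower number here means that less compound is needed, a higher number that more compound is needed for the effect. Compound 2 `CC(C)(C)OC(=O)N1CCC(Oc2ncnc3c2CCN3c2ccc(S(C)(=O)=O)cc2F)CC1` gives 20 nM in this assay. Compound 3 `CS(=O)(=O)c1ccc(N2CCc3c(OC4CCN(C(=O)OCCF)CC4)ncnc32)c(F)c1` gives 501 nM in this assay, level with compound 1 at the digits shown, the two together the highest of the three numbers, and furthest from compound 2. Among the measured compounds shown here, the one measured step, a 25-fold higher number from compound 2 to compound 3 (1.40 log units; beyond the scatter), shows how strongly this substituent on the ring nitrogen moves the read-out. Compound 4 `CN(C)C(=O)CN1CCC(Oc2ncnc3c2CCN3c2ccc(S(C)(=O)=O)cc2F)CC1` differs from compound 3 by (dimethylcarbamoyl)methyl in place of (2-fluoroethoxy)carbonyl on an amine nitrogen in a ring. For the measured compounds named here, no measured pair covers a (dimethylcarbamoyl)methyl group in this place, so the direction is open and only the scale of the earlier step is known. For compound 4 the estimate in this assay is 200 nM with a range of 30 nM to 1500 nM. The expected step is a 2.5-fold lower number from compound 3 to compound 4 (0.40 log units; beyond the scatter).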

Compound 4, half-maximal effective concentration: > 10000 nM
Compound 4: only a limit was reported; the forecaster's own chance of this, stated with the estimate: 5%; middle value at least 50-fold (1.69 log units) from the limit.
By their numbers in this assay, from the lowest: compound 2; then compounds 1 and 3 (each within the scatter of the next). At a limit, above all of these: compound 4.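

Compound 4 carries a limit of the assay and not a number: the limit of > 10000 nM in this assay, at which 1 of the 4 values shown sits. On the amine nitrogen in a ring, (dimethylcarbamoyl)methyl gives an at least 19-fold higher number from compound 3 to compound 4 (1.30 log units; beyond the scatter) and an at least 500-fold higher number from compound 2 to compound 4 (2.69 log units; beyond the scatter) in this assay. Among the compounds shown here, the earlier step compared only two oxygen-linked carbonyl groups, whereas this change shows that an equal heavy-atom count does not preserve the read-out here, since both groups in the step to compound 4 have the same count.

The shown compounds do not separate the effect of the amide from that of the methylene link. As far as these compounds go, a dimethylcarbamoyl group set directly on this nitrogen, or a plain alkyl chain, remains open.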